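The source may hold more compounds than are shown below. What is called first, only, known or untested is meant among the compounds shown, and "the series" means these compounds.

Measured so far:
compound 1 `N#Cc1ccc(OC[C@@H]2CCN2)cn1` — 1.9 nM
compound 2 `Cc1cncc(OC[C@@H]2CCN2)c1` — 0.047 nM

In an assay on brain for binding affinity to Neuronal acetylcholine receptor; alpha4/beta2 (Rattus norvegicus), read by radioligand binding (on this read-out higher numbers stand for weaker inhibition and lower numbers for stronger inhibition), compound 1 gives 1.9 nM and compound 2 gives 0.047 nM. Compound 2 therefore stands at the lower, stronger end of the two numbers, with compound 1 clearly beyond the scatter above it. Compound 3 `NCc1cncc(OC[C@@H]2CCN2)c1` carries amino in place of hydrogen on a saturated chain carbon bound to an aromatic carbon, read one bond further out as methyl to aminomethyl. Among the measured compounds shown here, no measured pair shows this change, so the expected step from compound 2 to compound 3 is a guess: a moderate rise toward weaker binding, an 11-fold higher number from compound 2 to compound 3 (1.03 log units; beyond the scatter). Compound 3 is expected to give 0.5 nM, within 0.08 nM to 3 nM.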

Compound 3, inhibition constant: 4.4 nM
The estimate for compound 3 lay 8.8-fold (0.94 log units) below the measured number, outside the stated range (above it).
By their numbers in this assay, from the lowest: compound 2; then compound 1; then compound 3.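

In this assay, amino in place of hydrogen on a saturated chain carbon bound to an aromatic carbon gives a large loss of binding, a 94-fold higher number from compound 2 to compound 3 (1.97 log units; beyond the scatter). So this position is sensitive: one added heavy atom, a nitrogen, is enough to move the number far beyond the scatter. Nothing available gives a cause for this step.

The compounds shown leave open whether hydroxymethyl or a longer chain ending in an amine would bring a step of similar size.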